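The source may hold more compounds than are shown below. What is called first, only, known or untested is meant among the compounds shown, and "the series" means these compounds.

Working notes on the series. In a functional assay on MCF7 cells (Homo sapiens) for cytotoxicity, read by MTT assay, with a stated time of 24 h (on this read-out lower numbers stand for stronger inhibition and higher numbers for weaker inhibition), compound 1 (`O=C(Nc1ccccc1)Nc1cccc2c(O)cccc12`) gives 953 nM and compound 2 (`O=C(Nc1cccc(C(F)(F)F)c1)Nc1cccc2c(Oc3ccc([N+](=O)[O-])cc3)cccc12`) gives 953 nM, so compound 2 stands level with compound 1, within the scatter. Compound 3 (`O=C(Nc1cccc(C(F)(F)F)c1)Nc1cccc2c(O)cccc12`) has not yet been measured. The structural change from compound 2 to compound 3 is hydrogen in place of 4-nitrophenyl on an oxygen on an aromatic ring, or 4-nitrophenoxy to hydroxy. For the measured compounds named here, no measured pair shows this change alone, so the data offer no direction for it. In this assay, no step beyond the scatter is expected, and neither direction is favoured. The estimate amounts to a 1.1-fold lower number from compound 2 to compound 3 (0.02 log units; within the scatter), an expected shift within the scatter. Compound 3 is estimated at 900 nM, with an expected range of 250 nM to 3000 nM.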

Compound 3, half-maximal inhibitory concentration: 953 nM
Estimate against measurement, compound 3: 1.1-fold (0.02 log units) below; the range from low to high includes it.
By their numbers in this assay, from the lowest: compounds 1, 2 and 3 (each within the scatter of the next).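

In this assay, for the compounds shown here, the hydroxy of compound 3 in place of the 4-nitrophenoxy of compound 2 gives no measurable step (no change at the digits printed from compound 2 to compound 3 (within the scatter)), so on this core a group as large as 4-nitrophenyl on the oxygen on an aromatic ring can be taken away without a shift beyond the scatter. Trifluoromethyl in place of hydrogen on an aromatic carbon, read with the hydroxy kept, likewise separates nothing (no change at the digits printed from compound 1 to compound 3 (within the scatter)), and neither change moves this read-out in the compounds shown. No measurement at hand accounts for the absence of a step in either change.

Going by these compounds, whether a methyl group or an acetic acid chain on that oxygen would read the same stays open. The same holds for an amine or a carboxylic acid in place of the trifluoromethyl.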